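Pyridine to methylthiazole on the shared core

This account rests on a few compounds, and the source may have more. Where it says the series, first, only, none or still open, it means among the compounds named here.

Compound 1 `c1ccc(-c2ccncc2)c(OCC2=NCCN2)c1` is assessed in a functional assay for activation of Alpha-1D adrenergic receptor (Homo sapiens), read by calcium flux; on this read-out lower numbers stand for an effect already at smaller amounts and higher numbers for an effect only at larger amounts of compound. In this assay compound 1 gives < 100000 nM, which is a limit of the assay and not a number, so compound 1 stands at the weak end of the three values shown. Compound 2 `c1ccc(-c2ccsc2)c(OCC2=NCCN2)c1` gives 12.6 nM in this assay. Compound 3 `c1ccc(-c2ncc[nH]2)c(OCC2=NCCN2)c1` gives < 100000 nM in this assay, again a limit and not a number. The step that the limit leaves unreadable from compound 1 to compound 2 and the step that the two limits leave unreadable from compound 1 to compound 3 cannot be sized because of the limit of < 100000 nM in this assay, at which 2 of the 3 values shown sit, and the same holds for the step that the limit leaves unreadable from compound 2 to compound 3.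

Compound 4 `Cc1csc(-c2ccccc2OCC2=NCCN2)n1` is not yet measured. It differs from compound 1 as follows: 4-methyl-1,3-thiazol-2-yl in place of pyridin-4-yl on an aromatic carbon. Within the data shown here, the group that enters shares the five-membered sulfur-containing ring of compound 2 and the ring nitrogen of compound 3, and the only readable number among the three is that of compound 2. The step from compound 1 to compound 4 is therefore expected to run toward smaller amounts, but its size is not readable from any measured step. The expected step is a step that the limit leaves unreadable from compound 1 to compound 4. The estimate for compound 4 in this assay is 300 nM, with a range from 10 nM to 10000 nM.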

Compound 4, half-maximal effective concentration: < 100000 nM
Compound 4: no number, only a limit; the forecaster's own chance of this, stated with the estimate: 25%; the middle value does not contradict the limit.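

In this assay compound 4 gives < 100000 nM, a limit of the assay and not a number. Among these compounds, no new step to compound 4 from compound 1, compound 2 or compound 3 can be read, because each rests on a limit: the limit of < 100000 nM in this assay, at which 3 of the 4 values shown sit.

The compounds shown leave open whether any group other than thiophen-3-yl on the shared core gives a readable number in this assay.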